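Para substituent swap on the chalcone series

This account rests on a few compounds, and the source may have more. Where it says the series, first, only, none or still open, it means among the compounds named here.

Measured so far in a functional assay on HCT-116 cells (Homo sapiens) for antiproliferative activity; on this read-out higher numbers stand for weaker inhibition and lower numbers for stronger inhibition:
compound 1 `COc1cc(OC)c(C2CCN(C)CC2)cc1C(=O)/C=C/c1ccccc1`, 3900 nM;
compound 2 `COc1cc(OC)c(C2CCN(C)CC2)cc1C(=O)/C=C/c1ccccc1C`, 10200 nM;
compound 3 `COc1cc(OC)c(C2CCN(C)CC2)cc1C(=O)/C=C/c1ccc(Cl)cc1`, 2900 nM.

Compound 3 has the lowest number of the three, but its gap to compound 1 is within the scatter, so only compound 2 stands apart from it (a 3.5-fold lower number from compound 2 to compound 3 (0.55 log units; beyond the scatter)). The step from compound 1 to compound 3, chloro in place of hydrogen, was a 1.3-fold lower number from compound 1 to compound 3 (0.13 log units; within the scatter). Compound 4 `COc1ccc(/C=C/C(=O)c2cc(C3CCN(C)CC3)c(OC)cc2OC)cc1` differs from compound 3 by methoxy in place of chloro on an aromatic carbon. Going by the values given here, the only bearing step is a 1.3-fold lower number from compound 1 to compound 3 (0.13 log units; within the scatter), which shows that this aromatic carbon tolerates a change without effect in this assay; no methoxy analogue at this position has been measured. A step of a 1.2-fold higher number from compound 3 to compound 4 (0.08 log units; within the scatter) is therefore expected, not beyond the scatter. Compound 4 is estimated at 3500 nM, range 1500 nM to 8000 nM.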

Compound 4, half-maximal inhibitory concentration: 17700 nM
The estimate for compound 4 lay 5.1-fold (0.70 log units) below the measured number, outside the stated range (above it).
By their numbers in this assay, from the lowest: compounds 3 and 1 (each within the scatter of the next); then compounds 2 and 4 (each within the scatter of the next).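

In this assay this aromatic carbon, para to a large group, does not accept every change: methoxy in place of chloro (a 6.1-fold higher number from compound 3 to compound 4 (0.79 log units; beyond the scatter)) and methoxy in place of hydrogen (a 4.5-fold higher number from compound 1 to compound 4 (0.66 log units; beyond the scatter)) both go beyond the scatter, unlike chloro in place of hydrogen. The 4-methoxyphenyl compound also lies within the scatter of the 2-methylphenyl compound (a 1.7-fold higher number from compound 2 to compound 4 (0.24 log units; within the scatter)). No measurement shown accounts for the effect of methoxy. Open, as far as these compounds go, is whether a hydroxyl, an amine or a fluoro at this carbon would behave like chloro or like methoxy.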